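The source may hold more compounds than are shown below. What is called first, only, known or untested is meant among the compounds shown, and "the series" means these compounds.

Compound 1 `O=C(/C(=C\c1ccc(O)c([N+](=O)[O-])c1)Sc1ccccc1Br)c1ccc(Br)cc1` gives 10000 nM in a functional assay on DU-145 cells (Homo sapiens) for inhibition, read by trypan blue exclusion, with a stated time of 96 h; on this read-out lower numbers stand for stronger inhibition of growth and higher numbers for weaker inhibition of growth. Among the three compounds measured there it stands second highest: compound 3 `O=C(/C(=C\c1ccc(O)c([N+](=O)[O-])c1)Sc1ccccc1Br)c1ccc(Cl)cc1` gives 25000 nM, and the step of a 2.5-fold higher number from compound 1 to compound 3 (0.40 log units; beyond the scatter) lies beyond the scatter, while compound 2 `O=C(/C(=C\c1ccc(OCc2ccccc2)cc1)S(=O)(=O)Cc1ccc(Cl)cc1)c1ccc(Cl)cc1` gives 1000 nM, a markedly lower number. Compound 4 `O=C(/C(=C\c1ccc(O)c([N+](=O)[O-])c1)SCc1ccc(Br)cc1)c1ccc(Br)cc1` has not yet been measured; it differs from compound 1 as 4-bromobenzyl in place of 2-bromophenyl on a sulfur. Among the compounds with values here, no measured step changes the group on the sulfur alone: the only single-point step, a 2.5-fold higher number from compound 1 to compound 3 (0.40 log units; beyond the scatter), concerns chloro in place of bromo on an aromatic carbon, and compound 2 differs from compound 1 in several places at once. No shift beyond the scatter is therefore expected in this assay. Compound 4 is expected to give 8000 nM, between 2500 nM and 25000 nM, a step of a 1.3-fold lower number from compound 1 to compound 4 (0.10 log units; within the scatter).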

Compound 4, concentration for 50% growth inhibition: 10000 nM
Estimate against measurement, compound 4: 1.3-fold (0.10 log units) below, within the range that was stated.
By their numbers in this assay, from the lowest: compound 2; then compounds 1 and 4 (each within the scatter of the next); then compound 3.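

Within the data shown here, measured in this assay the step of no change at the digits printed from compound 1 to compound 4 (within the scatter) is the first to change only the group on the sulfur, and it shows that 4-bromobenzyl can replace 2-bromophenyl there with no shift in the number. This position therefore tolerates this exchange, even though the entering group carries one more carbon. No measurement at hand accounts for this result.

The step alters the ring's attachment and the bromine's place together, so 2-bromobenzyl or 4-bromophenyl on the sulfur would be needed to separate them. On these data alone, whether unsubstituted benzyl or a chain ending in an amine would fare alike remains open.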